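The source may hold more compounds than are shown below. What is called first, only, known or untested is meant among the compounds shown, and "the series" means these compounds.

Compound 1 `Cc1cccc(NNC(=O)c2ccc(NS(=O)(=O)c3cnc(O)nc3O)cc2)c1` and compound 2 `CCCCOc1ccc(C(=O)NNC(=O)c2ccc(NS(=O)(=O)c3cnc(O)nc3O)cc2)cc1` share one core. In a functional assay on OVCAR-3 cells (Homo sapiens) for antiproliferative activity, read by MTT assay, with a stated time of 24 h (on this read-out higher numbers stand for weaker inhibition and lower numbers for stronger inhibition), compound 1 gives only a limit, > 20000 nM. Of the two results shown, compound 1 sits at the limit of > 20000 nM in this assay, at which 1 of the 2 values shown sits. In this assay compound 2 gives 12800 nM, the single number among the results shown. Compound 3 `O=C(NNC(=O)c1ccc(NS(=O)(=O)c2cnc(O)nc2O)cc1)c1ccc(F)cc1` differs from compound 2 by fluoro in place of butoxy on an aromatic carbon. Within the data shown here, no measured pair isolates this change, so in this assay only a small step toward weaker inhibition, close to the scatter, is expected: a 1.4-fold higher number from compound 2 to compound 3 (0.15 log units; within the scatter). Compound 3 is therefore estimated at 18000 nM, within 8000 nM to 40000 nM.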

Compound 3, half-maximal inhibitory concentration: > 20000 nM
Compound 3: only a limit was reported (the forecaster's own chance of this, stated with the estimate: 40%); middle value at least 1.1-fold (0.04 log units) away from the limit.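

Replacing butoxy with fluoro on this aromatic carbon leaves compound 3 with only a limit in this assay, > 20000 nM. Going by these compounds, the change gives an at least 1.5-fold higher number from compound 2 to compound 3 (0.19 log units; that floor lies within the scatter), so fluoro brings no stronger inhibition, but the size of the loss remains unknown and its floor does not clear the scatter. The step between the limits of compound 1 and compound 3 cannot be read.

On these data alone, how far compound 3 lies beyond its limit remains open. So does whether methoxy, a longer alkoxy chain or an amine at this position would give a readable number.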